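The compounds below may be only part of what the source reports. "The series", "measured", "known", "first", "only" and "open" are said of these compounds alone.

In an ADME assay (liver) for metabolic stability, with Liver microsome (Homo sapiens) as the target, using microsomes and NADPH, with a stated time of 30 min, tested at 1 uM (on this read-out higher numbers stand for fast clearance and lower numbers for slow clearance), compound 1 `CC(C)n1cc(-c2cc(C(O)(C(F)(F)F)C(F)(F)F)cnc2N2CCN(S(=O)(=O)c3ccc(N)nc3)CC2)cn1` gives 38 mL.min-1.g-1. Among the three measured compounds it holds the second highest number; its nearest neighbour is compound 3 `Nc1ccc(S(=O)(=O)N2CCN(c3ncc(C(O)(C(F)(F)F)C(F)(F)F)cc3-c3ccc4sccc4c3)CC2)cn1`, which gives 48 mL.min-1.g-1, and its furthest is compound 2 `Cc1csc(-c2cc(C(O)(C(F)(F)F)C(F)(F)F)cnc2N2CCN(S(=O)(=O)c3ccc(N)nc3)CC2)c1`, which gives 29 mL.min-1.g-1. The steps of a 1.3-fold higher number from compound 1 to compound 3 (0.10 log units; within the scatter) and a 1.3-fold lower number from compound 1 to compound 2 (0.12 log units; within the scatter) both lie within the scatter, as does a 1.7-fold higher number from compound 2 to compound 3 (0.22 log units; within the scatter), so the three numbers are not distinguishable from one another.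

Compound 4 `Nc1ccc(S(=O)(=O)N2CCN(c3ncc(C(O)(C(F)(F)F)C(F)(F)F)cc3-c3cc4ccccc4[nH]3)CC2)cn1` has not yet been measured in this assay. It differs from compound 1 in one place: 1H-indol-2-yl in place of 1-isopropyl-1H-pyrazol-4-yl on an aromatic carbon. Every measured step concerns a replacement on that same aromatic carbon of the shared core, and each of them stayed within the scatter, so no step beyond the scatter is expected here either. The estimate for compound 4 in this assay is therefore 45 mL.min-1.g-1, with an expected range from 22 mL.min-1.g-1 to 90 mL.min-1.g-1. The step of a 1.2-fold higher number from compound 1 to compound 4 (0.07 log units; within the scatter) that this estimate implies is expected to remain within the scatter.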

Compound 4, intrinsic clearance in microsomes: < 14 mL.min-1.g-1
Compound 4: only a limit was reported; the forecaster's own chance of this, stated with the estimate: 5%; middle value at least 3.2-fold (0.50 log units) away from the limit.
By their numbers in this assay, from the lowest: compounds 2, 1 and 3 (each within the scatter of the next). At a limit, below all of these: compound 4.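

In this assay compound 4 gives a limit and not a number: the limit of < 14 mL.min-1.g-1 in this assay, at which 1 of the 4 values shown sits. Within the data shown here, it is the first replacement on this aromatic carbon to give steps beyond the scatter (an at least 2.7-fold lower number from compound 1 to compound 4 (0.43 log units; beyond the scatter); an at least 2.0-fold lower number from compound 2 to compound 4 (0.31 log units; beyond the scatter); an at least 3.4-fold lower number from compound 3 to compound 4 (0.53 log units; beyond the scatter)), whereas the earlier replacements gave none. A second ring alone does not go with such a step, since 1-benzothiophen-5-yl in compound 3 stays within the scatter (a 1.3-fold higher number from compound 1 to compound 3 (0.10 log units; within the scatter)), so the position responds to 1H-indol-2-yl in particular.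

The compounds shown leave open how large the step really is, and whether it follows the hydrogen-bond donor that 1H-indol-2-yl brings. A 1-methyl-1H-indol-2-yl group or a 1H-indol-5-yl group on the same carbon would separate that donor from the point of attachment.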